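The source may report more compounds than this note shows. Statements on the series, on what has been measured and on what is new or still open speak of the compounds shown alone.

Going by the values given here, in a functional assay on HeLa cells (Homo sapiens) for antiproliferative activity, read by cell counting, with a stated time of 2 days (a higher number here means a weaker inhibitor, a lower number a stronger inhibitor), compound 2 `COc1ccc(Nc2nc(N)c(C(=O)c3ccc(Cl)cc3)s2)cc1` gives 83 nM, the lowest number of the three compounds measured so far. Compound 3 `COc1ccc(Nc2nc(N)c(C(=O)c3ccc([N+](=O)[O-])cc3)s2)cc1` follows at 350 nM, and compound 1 `COc1cccc(Nc2nc(N)c(C(=O)c3ccccc3)s2)c1` gives 3200 nM. Compound 4 `COc1ccc(Nc2nc(N)c(C(=O)c3ccccc3OC)s2)cc1`, still unmeasured, carries 2-methoxyphenyl in place of 4-chlorophenyl on a carbonyl carbon.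

Among the compounds with values here, only one measured change can serve as a guide: a 4.2-fold higher number from compound 2 to compound 3 (0.62 log units; beyond the scatter), a modest move beyond the scatter, with nitro in place of chloro on an aromatic carbon. Within the data shown here, that is a single example, and no measured compound carries the 2-methoxyphenyl group, so the guide is loose. Even so, the one replacement measured for the chloro-bearing group of compound 2 gave a higher number, which points the same way here, with a step of similar size expected in this assay. The estimated change is a 4.8-fold higher number from compound 2 to compound 4 (0.68 log units; beyond the scatter). For compound 4 the expected value is 400 nM, with an estimated range of 100 nM to 1800 nM.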

Compound 4, half-maximal inhibitory concentration: 17 nM
Compound 4: the middle estimate sits 24-fold (1.37 log units) above what was measured; the whole stated range lies above it.
By their numbers in this assay, from the lowest: compound 4; then compound 2; then compound 3; then compound 1.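

In this assay, the group on the carbonyl carbon can be changed to give a lower number as well as a higher one: 2-methoxyphenyl in place of 4-chlorophenyl brings a 4.9-fold lower number from compound 2 to compound 4 (0.69 log units; beyond the scatter). Going by these compounds alone, the only earlier change to this part of compound 2, nitro in place of chloro, had gone the other way, with a 4.2-fold higher number from compound 2 to compound 3 (0.62 log units; beyond the scatter), so the two changes now show that the number can move in either direction when this aryl group is altered. No other measurement bears on why the number fell.

This single change removes the chlorine and brings in the methoxy group together, so the compounds shown cannot separate the two. Going by these compounds, it also remains open whether an ethoxy group or an amine in place of the methoxy group would keep the number this low.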